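Swapping Sulfur for Selenium in Compound 1

The source may report more compounds than this note shows. Statements on the series, on what has been measured and on what is new or still open speak of the compounds shown alone.

In a functional assay on HepG2 cells (Homo sapiens) for cytotoxicity, read by MTT assay, with a stated time of 72 h (on this read-out higher numbers stand for lower toxicity in this test and lower numbers for higher toxicity in this test), compound 1 `CS/C(=N\C(=O)c1csc([N+](=O)[O-])c1)NC(=O)c1csc([N+](=O)[O-])c1` gives only > 100000 nM, which is a limit of the test and not a number, and it sits where (the limit of > 100000 nM in this assay, at which 1 of the 3 values shown sits). Two selenium-bearing relatives have numbers: compound 2 `O=C(/N=C(/NC(=O)c1cccs1)[Se]Cc1ccccc1)c1cccs1` gives 81500 nM in this assay, and compound 3 `O=C(/N=C(/NC(=O)c1cnc2ccccc2c1)[Se]Cc1ccccc1)c1cnc2ccccc2c1` gives 90300 nM in this assay. Those two values lie within the usual scatter of each other.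

Compound 4 `C[Se]/C(=N\C(=O)c1csc([N+](=O)[O-])c1)NC(=O)c1csc([N+](=O)[O-])c1` differs from compound 1 in one place: a group of 2 heavy atoms (1 carbon, 1 selenium; no ring) in place of a group of 2 heavy atoms (1 carbon, 1 sulfur; no ring), on a carbon with a double bond to nitrogen. For the measured compounds named here, no measured pair shows this exchange on its own, so its size is not known from the compounds in hand. Since compound 1 sits at the limit and compound 2 and compound 3 both carry selenium with little toxicity, the step is expected to be small, a number no higher from compound 1 to compound 4 (the limit leaves the size open), within the usual scatter and with no clear direction. The estimate for compound 4 in this assay is 100000 nM, with a range from 50000 nM to 200000 nM, and a fair chance that the test again reports only a limit.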

Compound 4, concentration lethal to 50% of the cells: 10000 nM
Estimate against measurement, compound 4: 10-fold (1.00 log units) above; measured number outside the range, below it.
By their numbers in this assay, from the lowest: compound 4; then compounds 2 and 3 (each within the scatter of the next). At a limit, above all of these: compound 1.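

In this assay, the exchange of methylsulfanyl for its selenium counterpart, on a carbon with a double bond to nitrogen, can now be read on its own, and it gives an at least 10-fold lower number from compound 1 to compound 4 (1.00 log units; beyond the scatter). With the rest of the core of compound 1 unchanged, this one exchange at this place is enough to move the read-out beyond the usual scatter, towards higher toxicity in this test. The full size of the step stays unfixed because the value for compound 1 is only a limit: the limit of > 100000 nM in this assay, at which 1 of the 4 values shown sits.

The compounds shown do not say why the exchange has this effect, or whether it would have the same effect on a different core. Nor do they show what an ethyl chain or an amine in the same place would do to the read-out.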